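This account rests on a few compounds, and the source may have more. Where it says the series, first, only, none or still open, it means among the compounds named here.

Three compounds measured so far in an ADME assay for permeability, using PAMPA; on this read-out lower numbers stand for lower permeability and higher numbers for higher permeability

- compound 1 `COc1cc(N2CCN(C(=O)C3CCC(O)CC3)CC2)ccc1Nc1nc(NC2CCCCC2)c2nc[nH]c2n1` gives 81 10^-6 cm/s
- compound 2 `COc1cc(N2CCN(C(=O)N3CCN(C)CC3)CC2)ccc1Nc1nc(NC2CCCCC2)c2nc[nH]c2n1` gives "impermeable" (no number reported)
- compound 3 `COc1cc(N2CCN(Cc3ccccn3)CC2)ccc1Nc1nc(NC2CCCCC2)c2nc[nH]c2n1` gives 976 10^-6 cm/s

Compound 3 holds the higher of the two numbers, while compound 2 gave no number at all. Compound 4 `COc1cc(N2CCN(C(=O)N3CCC(O)C3)CC2)ccc1Nc1nc(NC2CCCCC2)c2nc[nH]c2n1` has (3-hydroxypyrrolidin-1-yl)carbonyl in place of the (pyridin-2-yl)methyl of compound 3 on an amine nitrogen in a ring (3-hydroxypyrrolidin-1-yl)carbonyl in place of (pyridin-2-yl)methyl on an amine nitrogen in a ring and so also carries a hydroxyl-bearing carbonyl group, much as compound 1 does. Among the compounds with values here, the one measured step at this place is a 12-fold higher number from compound 1 to compound 3 (1.08 log units; beyond the scatter) and it is large. Running the other way, the new change is expected to give a fall of similar size, well beyond the scatter, namely a 14-fold lower number from compound 3 to compound 4 (1.14 log units; beyond the scatter) in this assay here. Compound 2 also has a carbonyl group at this place, and its result of "impermeable" (no number reported) means that a report without a number is possible. Compound 4 is estimated at 70 10^-6 cm/s (10 10^-6 cm/s to 350 10^-6 cm/s).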

Compound 4, apparent permeability: "impermeable" (no number reported)
Compound 4 has no reported number here; no gap can be computed for the estimate.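

Compound 4 gave no number in this assay, so no step from compound 3 to compound 4 can be read, and nothing shown bears on this result. As far as these compounds go, how compound 2 and compound 4 stand numerically against compound 1 and compound 3 remains open.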